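Methyl to cyclopropyl on the shared core

The compounds below may be only part of what the source reports. "The series", "measured", "known", "first", "only" and "open" are said of these compounds alone.

Measured so far:
compound 1 `CCCc1c(C(=O)N[C@@H](C)c2ccc(C(=O)O)cc2)nnn1Cc1ccc(C(F)(F)F)cc1`: > 10000 nM
compound 2 `Cc1nnn(Cc2ccc(C(F)(F)F)cc2)c1C(=O)N[C@@H](C)c1ccc(C(=O)O)cc1`: > 10000 nM

Both compounds were run in a functional assay on CHO cells for antagonist activity at prostaglandin E2 receptor EP4 subtype (Homo sapiens), read by calcium flux, with a stated time of 15 min; a lower number here means a stronger inhibitor, a higher number a weaker inhibitor. Compound 1 gives > 10000 nM, which is a limit of the assay and not a number. Compound 2 likewise gives > 10000 nM, again a limit rather than a measured value. On the numbers shown, compound 2 therefore stands at the limit of > 10000 nM in this assay, at which 2 of the 2 values shown sit. Among the compounds with values here, no step between measured compounds is available, so there is nothing yet to scale a structural change against.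

Compound 3 `C[C@H](NC(=O)c1c(C2CC2)nnn1Cc1ccc(C(F)(F)F)cc1)c1ccc(C(=O)O)cc1` differs from compound 2 in one place: cyclopropyl in place of methyl on an aromatic carbon of the five-membered aromatic ring with 3 nitrogen. With the reference value itself a limit, the expected step is a number no higher from compound 2 to compound 3 (the limit leaves the size open), none beyond the scatter, most likely ending again at the limit. Compound 3 is accordingly estimated at 10000 nM, with a range of 3000 nM to 30000 nM.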

Compound 3, half-maximal inhibitory concentration: 52.1 nM
Beside the measured number, compound 3's estimate is 190-fold (2.28 log units) above it; the measured number lies below the stated range.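

Cyclopropyl in place of methyl on this aromatic carbon of the five-membered aromatic ring with 3 nitrogen is the first change in the series to bring activity into the measurable range of this assay, with an at least 190-fold lower number from compound 2 to compound 3 (2.28 log units; beyond the scatter). Compound 1, with a propyl chain at the same carbon, gives > 10000 nM, which is a limit of the assay, so replacing methyl with a larger alkyl group does not by itself produce a measured number among the compounds shown. Compound 3 is the only compound here with a measured number, and the other two remain at the limit: the limit of > 10000 nM in this assay, at which 2 of the 3 values shown sit.

On these data alone, the full size of the step stays open, as its starting point is a limit. Whether an isopropyl or cyclobutyl group at this carbon would also give a measured number also remains open, as does what in the cyclopropyl group accounts for the change.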